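This account rests on a few compounds, and the source may have more. Where it says the series, first, only, none or still open, it means among the compounds named here.

Working notes on the series.

Compound 1 `O[C@@H](c1ccccc1)[C@H]1CO[C@H](c2ccccc2)[C@@H](C/C=C/c2ccncc2)C1` is the starting point. In a functional assay on HeLa cells (Homo sapiens) for cytotoxicity, read by WST assay, with a stated time of 48 h (a higher number here means a weaker inhibitor, a lower number a stronger inhibitor), compound 1 gives only a limit, > 100000 nM, so no number stands for it, and among the three values shown it is the one that sits at the limit of > 100000 nM in this assay, at which 1 of the 3 values shown sits. Compound 2 `COc1ccc([C@H]2OC[C@H]([C@@H](O)c3ccc(OC)c(OC)c3)C[C@@H]2C/C=C/c2ccccc2)cc1OC` and compound 3 `COc1ccc(CCC[C@H]2C[C@@H]([C@@H](O)c3ccc(OC)c(OC)c3)CO[C@@H]2c2ccc(OC)c(OC)c2)cc1OC` share the core but differ from compound 1 in more than one place; compound 2 gives 14800 nM in this assay, and compound 3 gives 37700 nM. For the measured compounds named here, the one step between measured compounds that differ in a single place is a 2.5-fold higher number from compound 2 to compound 3 (0.41 log units; beyond the scatter); it concerns a change on a saturated chain carbon, not the aromatic end of the double-bonded chain, so it does not bear directly on the change considered here.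

Compound 4 `O=[N+]([O-])c1ccc(/C=C/C[C@H]2C[C@@H]([C@@H](O)c3ccccc3)CO[C@@H]2c2ccccc2)cc1` differs from compound 1 by 4-nitrophenyl in place of pyridin-4-yl on a double-bonded chain carbon bound to a double-bonded chain carbon. Going by the values given here, no measured pair isolates this exchange, and compound 1 itself is known only as a limit, so the direction and size of the step are open. Given that compound 2 and compound 3 remain weak in this assay and compound 1 sits at the limit, compound 4 is expected to stay weak, with an estimated step of an at least 1.6-fold lower number from compound 1 to compound 4 (0.22 log units; that floor lies within the scatter). The estimate for compound 4 in this assay is 60000 nM, with a range from 15000 nM to 200000 nM.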

Compound 4, half-maximal inhibitory concentration: 12400 nM
The estimate for compound 4 lay 4.8-fold (0.68 log units) above the measured number; the measured number lies below the stated range.
By their numbers in this assay, from the lowest: compounds 4 and 2 (each within the scatter of the next); then compound 3. At a limit, above all of these: compound 1.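

The exchange of pyridin-4-yl for 4-nitrophenyl on a double-bonded chain carbon bound to a double-bonded chain carbon can now be read directly in this assay, as an at least 8.0-fold lower number from compound 1 to compound 4 (0.90 log units; beyond the scatter). For the compounds shown here, earlier, the only single-place step concerned a saturated chain carbon, so this is the first sign that the group at this position matters: with the rest of compound 1 unchanged, this one exchange turns a limit into a measured number. The step is a floor and not a full size because compound 1 has only a limit, not a number: the limit of > 100000 nM in this assay, at which 1 of the 4 values shown sits.

The compounds shown do not separate the two parts of the exchange, the carbon-only ring in place of the ring with a hetero atom and the added nitro group, and a plain phenyl on the same chain with the core of compound 1 would be needed to tell them apart. From the compounds shown here alone, it also remains open whether an amine or a carboxylic acid in the place of the nitro group on that ring would keep, extend or lose the step in this assay.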